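This account rests on a few compounds, and the source may have more. Where it says the series, first, only, none or still open, it means among the compounds named here.

Compound 1 `CCn1c(C(=O)NCCCN(C)C)ccc1C(CC)(CC)c1ccc(OCCC(O)(CC)CC)c(C)c1`: 110 nM
Compound 2 `CCn1c(C(=O)NCCN)ccc1C(CC)(CC)c1ccc(OCCC(O)(CC)CC)c(C)c1`: 1590 nM

In a functional assay on HepG2 cells (Homo sapiens) for antiproliferative activity, read by MTT assay, with a stated time of 48 h (on this read-out higher numbers stand for weaker inhibition and lower numbers for stronger inhibition), compound 2 gives the higher of the two numbers, and compound 1 gives 110 nM. Compound 3 `CCOC(=O)CN(C)C(=O)c1ccc(C(CC)(CC)c2ccc(OCCC(O)(CC)CC)c(C)c2)n1CC` differs from compound 2 by ((ethoxycarbonyl)methyl)(methyl)amino in place of (2-aminoethyl)amino on a carbonyl carbon. Within the data shown here, the one measured step, a 14-fold higher number from compound 1 to compound 2 (1.16 log units; beyond the scatter), concerns a different change on the same chain and bears on this only loosely. Compound 3 is therefore expected to stay near compound 2, with a step of a 1.3-fold higher number from compound 2 to compound 3 (0.10 log units; within the scatter), in no clear direction beyond the scatter. The estimate for compound 3 is 2000 nM, between 500 nM and 8000 nM.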

Compound 3, half-maximal inhibitory concentration: 25300 nM
Compound 3: middle estimate off by 13-fold (1.10 log units), on the low side, and the stated range ends below it.
By their numbers in this assay, from the lowest: compound 1; then compound 2; then compound 3.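

In this assay, the change on the carbonyl carbon costs more than the earlier change on the chain: ((ethoxycarbonyl)methyl)(methyl)amino gives a 16-fold higher number from compound 2 to compound 3 (1.20 log units; beyond the scatter), and against the (3-(dimethylamino)propyl)amino group it gives a 230-fold higher number from compound 1 to compound 3 (2.36 log units; beyond the scatter). Compounds 1 and 2 both keep an amine on the chain and the amide hydrogen, whereas compound 3 has neither. Nothing measured here explains the loss. The change alters several features at once, so the compounds shown do not separate the ethyl ester, the methyl group and the lost amine. They also leave open how a carboxylic acid in place of the ethyl ester would read.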